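The compounds below may be only part of what the source reports. "The series", "measured", "known", "first", "only" and "open" are said of these compounds alone.

Within the data shown here, compound 2, `Cc1ccccc1-n1nc(C)c2c1NC(=O)[C@H](C)S[C@@H]2c1ccc(-c2ccco2)cc1`, gives 32% in an assay on isolated protein for agonist activity at Bile acid receptor (Homo sapiens), read by AlphaScreen, with a stated time of 30 min (a lower number here means a smaller maximal response, a higher number a larger maximal response), the higher of the two numbers measured so far. Compound 1, `Cc1ccccc1-n1nc(C)c2c1NC(=O)[C@H](C)S[C@@H]2c1ccc(-c2cc3ccccc3o2)cc1`, gives 17% in this assay, and the step of a number 15 percentage points higher from compound 1 to compound 2 (beyond the scatter) is modest yet beyond the scatter. Compound 3, `COc1cccc(Oc2ccc([C@H]3S[C@@H](C)C(=O)Nc4c3c(C)nn4-c3ccccc3C)cc2)c1`, differs from compound 2 in one place: 3-methoxyphenoxy in place of furan-2-yl on an aromatic carbon. Among the measured compounds shown here, the only measured step that speaks to this position is the one in which furan-2-yl replaced 1-benzofuran-2-yl, and there the smaller group went with a larger maximal response, as the step of a number 15 percentage points higher from compound 1 to compound 2 (beyond the scatter) shows. The change to 3-methoxyphenoxy moves in the opposite sense, toward a larger group on the same aromatic carbon, so a decrease of similar, modest size is expected. The maximal response of compound 3 in this assay is therefore estimated at 22%, between 8% and 38%. This means an expected step of a number 10 percentage points lower from compound 2 to compound 3 (within the scatter).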

Compound 3, largest response reached (reported as efficacy), in percent of the reference or control that the assay uses: 120%
The estimate for compound 3 lay 98 percentage points below the measured number; measured number outside the range, above it.
By their numbers in this assay, from the lowest: compound 1; then compound 2; then compound 3.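

The step to 3-methoxyphenoxy is far larger than the earlier change at this position: in this assay it gives a number 88 percentage points higher from compound 2 to compound 3 (beyond the scatter) and a number 103 percentage points higher from compound 1 to compound 3 (beyond the scatter). A group with more heavy atoms than furan-2-yl can therefore sit on this aromatic carbon and still give the largest maximal response of the three compounds, so the earlier gain on going from 1-benzofuran-2-yl to furan-2-yl does not reflect a general preference for a smaller group here. No measurement is at hand that explains this jump.

The compounds shown leave open which part of 3-methoxyphenoxy carries the gain, the ring oxygen link or the methoxy group. They also leave open how a plain phenoxy or a directly attached phenyl group would compare at this position.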